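A few compounds are considered here, and "the series" means these few. Any claim that something is new, unique, unknown or untested is made for them only; others in the source may bear on it.

In an ADME assay on RAW264.7 cells (Mus musculus) for cytotoxicity, read by MTT assay, with a stated time of 72 h, tested at 100 uM (a lower number here means a weaker effect, a higher number a stronger effect of the compound at the concentration tested), compound 1 `O=C(Cn1c(=O)oc2cc(Cl)ccc21)Nc1nc2ccccc2s1` gives 52.5%. Compound 2 `O=C(Cn1c(=O)oc2cc([N+](=O)[O-])ccc21)NCc1ccccn1` gives 33.4% in this assay, the lower of the two numbers recorded so far, sitting under compound 1 by a gap beyond the usual scatter. Compound 3 `O=C(Cn1c(=O)oc2cc([N+](=O)[O-])ccc21)NCc1cccs1` has not yet been tested; it differs from compound 2 in one place: thiophen-2-yl in place of pyridin-2-yl on a saturated chain carbon bound to an amide-type nitrogen. Among the compounds with values here, no pair of measured compounds shows this change on its own, so nothing here tells how large its effect might be. The expected step is small, a number 0.4 percentage points lower from compound 2 to compound 3 (within the scatter), none beyond the scatter. Compound 3 is therefore estimated at 33%, within a range from 15% to 52%.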

Compound 3, a percentage reported as inhibition, at one concentration (the size of the read-out at that concentration, not a potency): 41%
Compound 3: the middle estimate sits 8 percentage points below what was measured, within the range that was stated.
By their numbers in this assay, from the lowest: compounds 2 and 3 (each within the scatter of the next); then compound 1.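

In this assay, thiophen-2-yl in place of pyridin-2-yl on a saturated chain carbon bound to an amide-type nitrogen gives a number 7.6 percentage points higher from compound 2 to compound 3 (within the scatter). Within the data shown here, this is the first direct reading of a change at this position, and exchanging these two aromatic rings, one five-membered with sulfur and one six-membered with nitrogen, leaves no difference that can be told from scatter. No available evidence bears on this result. Still open, going by these compounds, is whether a non-aromatic group at the same place, such as cyclohexyl or a dimethylamino group, would give a clearly different number. On these data alone, whether the same exchange behaves alike on a different core also remains unknown.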